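Halogen swap on the N-aryl ring of the pyridazinone amides

The compounds below may be only part of what the source reports. "The series", "measured", "known", "first", "only" and "open" are said of these compounds alone.

Three compounds share one core and differ only in the aryl group on the ring nitrogen. Compound 1 `Cc1cc(=O)n(-c2ccccc2C(F)(F)F)nc1C(=O)Nc1ccc(Oc2ncnc3ccsc23)c(F)c1` carries a 2-trifluoromethylphenyl and gives 6020 nM in a functional assay on MCF7 cells (Homo sapiens) for cytotoxicity, read by MTT assay, with a stated time of 72 h; on this read-out higher numbers stand for weaker inhibition and lower numbers for stronger inhibition. Compound 2 `O=C(Nc1ccc(Oc2ncnc3ccsc23)c(F)c1)c1nn(-c2ccc(F)cc2)ccc1=O` carries a 4-fluorophenyl and gives 5720 nM in this assay. Compound 3 `O=C(Nc1ccc(Oc2ncnc3ccsc23)c(F)c1)c1nn(-c2ccc(F)c(Cl)c2)ccc1=O` carries a 3-chloro-4-fluorophenyl and gives 6630 nM in this assay. The three values lie within the scatter of one another, so compound 3 is not set apart from compound 1 or compound 2.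

Compound 4 `O=C(Nc1ccc(Oc2ncnc3ccsc23)c(F)c1)c1nn(-c2ccc(Br)cc2)ccc1=O` differs from compound 3 by 4-bromophenyl in place of 3-chloro-4-fluorophenyl on an aromatic nitrogen. Going by the values given here, the only measured step that bears on this change is a 1.2-fold higher number from compound 2 to compound 3 (0.06 log units; within the scatter), a halogen change on the same aryl ring that left the number unchanged within the scatter. On that basis no step beyond the scatter is expected from compound 3 to compound 4, and the estimated step is a 1.1-fold lower number from compound 3 to compound 4 (0.03 log units; within the scatter). Compound 4 is therefore expected to give about 6200 nM in this assay, with a range from 3000 nM to 13000 nM.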

Compound 4, half-maximal inhibitory concentration: 9620 nM
For compound 4 the middle estimate is 1.6-fold (0.19 log units) below the measured one; the measured number falls inside the stated range.
By their numbers in this assay, from the lowest: compounds 2, 1, 3 and 4 (each within the scatter of the next).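

Bromo on this aryl ring appears only in compound 4, and in this assay bromo in place of fluoro on an aromatic carbon gives a 1.7-fold higher number from compound 2 to compound 4 (0.23 log units; within the scatter). Replacing the two-halogen 3-chloro-4-fluorophenyl with the single-halogen 4-bromophenyl on the aromatic nitrogen gives a 1.5-fold higher number from compound 3 to compound 4 (0.16 log units; within the scatter), so neither change separates compound 4 from its neighbour in the series. No measurement to hand accounts for the size of these steps.

With each compound within the scatter of the next, no aryl group on this nitrogen is yet set apart from the others. Still open, on these data alone, is whether an amine or a carboxylic acid on this aryl ring, in place of the halogens, would shift the number beyond the scatter.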